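One Chlorine Less on the Ring: An Expected Step

The source may report more compounds than this note shows. Statements on the series, on what has been measured and on what is new or still open speak of the compounds shown alone.

Three compounds were tested in a functional assay on BGC-823 cells (Homo sapiens) for cytotoxicity, read by CCK-8 assay, with a stated time of 72 h; on this read-out lower numbers stand for stronger inhibition and higher numbers for weaker inhibition. Compound 2 `C=CCn1c(=O)/c(=C\c2cccc(Cl)c2Cl)[nH]c(=O)/c1=C\c1ccccc1OC` gives 2200 nM. Compound 1 `C=CCn1c(=O)/c(=C\c2ccccc2Cl)[nH]c(=O)/c1=C\c1ccccc1OC` gives 4600 nM, and the step from compound 2 to compound 1, a 2.1-fold higher number from compound 2 to compound 1 (0.32 log units; beyond the scatter), comes from the change (hydrogen in place of chloro on an aromatic carbon). Compound 3 `COc1ccccc1/C=c1\c(=O)[nH]/c(=C/c2cccc(Cl)c2Cl)c(=O)n1C` gives 300 nM, the lowest of the three numbers; its core differs from the core of compound 2 by hydrogen in place of vinyl on a saturated chain carbon bound to an aromatic nitrogen, which made the step of a 7.3-fold lower number from compound 2 to compound 3 (0.87 log units; beyond the scatter).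

Compound 4 `COc1ccccc1/C=c1\c(=O)[nH]/c(=C/c2ccccc2Cl)c(=O)n1C` has not yet been measured in this assay. It differs from compound 3 by hydrogen in place of chloro on an aromatic carbon, the same change already seen from compound 2 to compound 1, at the same place on the ring. Resting on the earlier step of a 2.1-fold higher number from compound 2 to compound 1 (0.32 log units; beyond the scatter), the same change is expected to give a 2.2-fold higher number from compound 3 to compound 4 (0.34 log units; beyond the scatter). Compound 4 is therefore estimated at 650 nM, with a likely range from 300 nM to 1400 nM.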

Compound 4, half-maximal inhibitory concentration: 300 nM
Estimate against measurement, compound 4: 2.2-fold (0.34 log units) above, within the range that was stated.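

In this assay, going from 2,3-dichlorophenyl to 2-chlorophenyl gives no change at the digits printed from compound 3 to compound 4 (within the scatter) and so looks different from the earlier step, yet the two readings still agree: the same change on two cores in this assay, a 2.1-fold higher number (0.32 log units; beyond the scatter) from compound 2 to compound 1 and no change at the digits printed (within the scatter) from compound 3 to compound 4, 2.1-fold (0.32 log units) apart, within the scatter of two such steps.

The other change, hydrogen in place of vinyl on the chain carbon bound to the aromatic nitrogen, gives a 15-fold lower number from compound 1 to compound 4 (1.19 log units; beyond the scatter) and also carries over: the same change on two cores in this assay, a 7.3-fold lower number (0.87 log units; beyond the scatter) from compound 2 to compound 3 and a 15-fold lower number (1.19 log units; beyond the scatter) from compound 1 to compound 4, 2.1-fold (0.32 log units) apart, within the scatter of two such steps.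

Both changes therefore travel between these two cores within the scatter, but this is a single pair of cores, so it does not show that either change would hold on a further core.

Still open, going by these compounds, is what other groups would do in place of the chloro, such as a bromo group or a nitrile. Also open, on these data alone, is what a longer chain on the aromatic nitrogen would give.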